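Ring size on the amide nitrogen: cyclobutyl analogue

The compounds below may be only part of what the source reports. "The series", "measured", "known", "first", "only" and "open" are said of these compounds alone.

Compound 1 `Nc1sc(-c2ccc(Cl)cc2)c(-c2ccc(Cl)cc2)c1C(=O)NC1CCCC1` gives the highest of the two numbers in a functional assay on PC-3 cells (Homo sapiens) for inhibition, read by sulforhodamine B assay, with a stated time of 72 h (a lower number here means a stronger inhibitor, a higher number a weaker inhibitor), at 21200 nM. Going by the values given here, its only neighbour is compound 2 `Nc1sc(-c2ccc(Cl)cc2)c(-c2ccc(Cl)cc2)c1C(=O)NC1CC1`, which in this assay gives 3680 nM; the step of a 5.8-fold lower number from compound 1 to compound 2 (0.76 log units; beyond the scatter) is the one measured change of this kind. Compound 3 `Nc1sc(-c2ccc(Cl)cc2)c(-c2ccc(Cl)cc2)c1C(=O)NC1CCC1` differs from compound 1 by cyclobutyl in place of cyclopentyl on an amide-type nitrogen. The cyclobutyl sits between the two measured rings, so a step smaller than that to compound 2 is expected, in the same direction, a 2.5-fold lower number from compound 1 to compound 3 (0.40 log units; beyond the scatter). For compound 3 in this assay the estimate is 8500 nM, with a range from 3000 nM to 25000 nM.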

Compound 3, half-maximal inhibitory concentration: 24800 nM
The estimate for compound 3 lay 2.9-fold (0.47 log units) below the measured number; measured number inside the range.
By their numbers in this assay, from the lowest: compound 2; then compounds 1 and 3 (each within the scatter of the next).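

In this assay, the number does not follow ring size stepwise: a 1.2-fold higher number from compound 1 to compound 3 (0.07 log units; within the scatter) leaves cyclobutyl and cyclopentyl level on the amide-type nitrogen, whereas a 6.7-fold higher number from compound 2 to compound 3 (0.83 log units; beyond the scatter) sets cyclopropyl apart from cyclobutyl. Of these three compounds, only compound 2 stands apart, so the lower number goes with cyclopropyl alone and not with shrinking the ring in general. Nothing at hand accounts for this difference.

Still open, from the compounds shown here alone, is whether an open-chain group such as isopropyl would match cyclopropyl at this position. A ring carrying an amine, such as piperidin-4-yl, is equally untested here.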